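The source may hold more compounds than are shown below. What is called first, only, known or untested is meant among the compounds shown, and "the series" means these compounds.

In a functional assay, read by fluorescence and spectrophotometry, with a stated time of 1 h (on this read-out lower numbers stand for an effect already at smaller amounts and higher numbers for an effect only at larger amounts of compound), compound 3 (`O=S(=O)(/C=C/c1ccc(O)c(O)c1)CC1CC1`) gives 10500 nM and sits level with compound 1 (`CCCCCCCCCCCCS(=O)(=O)/C=C/c1ccc(O)c(O)c1`) at 8500 nM and compound 2 (`O=S(=O)(/C=C/c1ccc(O)c(O)c1)CCC1CCCCC1`) at 9800 nM with all three numbers inside the usual scatter of one another. These three compounds share one core and differ only in the group on the sulfonyl sulfur. The next compound, compound 4 (`CCCCCCS(=O)(=O)/C=C/c1ccc(O)c(O)c1`), has not yet been measured, and it changes that same place: pentyl in place of cyclopropyl on a saturated chain carbon bound to a sulfonyl sulfur which in words means pentyl in place of cyclopropyl on a saturated chain carbon bound to a sulfonyl sulfur. Among the compounds with values here, the one measured step at this place is a 1.1-fold higher number from compound 2 to compound 3 (0.03 log units; within the scatter) with cyclopropyl in place of cyclohexylmethyl, and that swap gave no difference that can be told from the scatter. Like compound 4, compound 1 carries a chain with no ring, and compound 1 gives 8500 nM in the same band. Within the data shown here, no measured compound carries the pentyl group itself, so some uncertainty remains. Even so, no step beyond the scatter is expected in this assay in either direction. The expected step is a 1.1-fold lower number from compound 3 to compound 4 (0.04 log units; within the scatter) and so should stay small. Compound 4 is estimated at 9500 nM with an expected range from 5000 nM to 18000 nM once it is tested.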

Compound 4, half-maximal effective concentration: 7300 nM
Compound 4: the middle estimate sits 1.3-fold (0.11 log units) above what was measured, within the range that was stated.
By their numbers in this assay, from the lowest: compounds 4, 1, 2 and 3 (each within the scatter of the next).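

In this assay, pentyl in place of cyclopropyl on a saturated chain carbon bound to a sulfonyl sulfur gives a 1.4-fold lower number from compound 3 to compound 4 (0.16 log units; within the scatter) and so shows that opening the ring into a chain, a kind of swap not yet seen at this place, leaves no difference that can be told from the scatter. Butyl in place of cyclohexyl on a saturated chain carbon, two bonds along the chain from a sulfonyl sulfur, gives a 1.3-fold lower number from compound 2 to compound 4 (0.13 log units; within the scatter) and hydrogen in place of hexyl on a saturated chain carbon, six bonds along the chain from a sulfonyl sulfur, gives a 1.2-fold lower number from compound 1 to compound 4 (0.07 log units; within the scatter) so shortening a long chain or removing a ring from a ring-bearing one does not separate the compounds either. All four compounds, with or without a ring and with groups of quite different length on the sulfonyl sulfur, therefore stay in one band in this assay and none can be ranked above another.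

The groups shown at this place hold carbon and hydrogen only, so whether an amine or a carboxylic acid on the chain would shift the number remains open. Nothing measured here explains why the number stays so flat across these groups.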